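This account rests on a few compounds, and the source may have more. Where it says the series, first, only, none or still open, it means among the compounds named here.

Measured so far:
- compound 1, `COc1cccc(CNCCCNc2ccnc3cc(Oc4ccc(Cl)cc4)ccc23)c1O`: 14500 nM
- compound 2, `COc1ccc(F)cc1CNCCCNc1ccnc2cc(CCc3ccccc3)ccc12`: 4200 nM

Of the compounds shown here, two have been measured in a physicochemical assay for solubility, with a stated time of 18 h, at pH 7.4; on this read-out higher numbers stand for higher solubility and lower numbers for lower solubility. Compound 1 gives 14500 nM and stands as the higher of the two numbers; compound 2 gives 4200 nM, and the gap between them lies beyond the usual scatter of the measurement. No pair of these compounds differs in only one place, so no single step can be read from them.

Compound 3, `COc1cccc(CNCCCNc2ccnc3cc(Cc4ccc(F)cc4Cl)ccc23)c1O`, has not yet been measured. It departs from compound 1 in one place: 2-chloro-4-fluorobenzyl in place of 4-chlorophenoxy on an aromatic carbon. The group that leaves carries one hydrogen-bond acceptor, the group that enters carries none, and the shared core is otherwise kept. Going by the values given here, no measured step tells how this assay responds to such a swap. Among the compounds with values here, still, a decrease beyond the scatter is expected, since the only other measured compound, compound 2, which has no oxygen-linked group on the core, gives the lower value 4200 nM. For compound 3 the expected step is a 2.9-fold lower number from compound 1 to compound 3 (0.46 log units; beyond the scatter), a fall in solubility. Compound 3 is therefore estimated at 5000 nM, in a range from 1500 nM to 15000 nM.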

Compound 3, solubility: 4200 nM
Estimate against measurement, compound 3: 1.2-fold (0.08 log units) above, and the stated range covers the measured number.
By their numbers in this assay, from the lowest: compounds 2 and 3 (each within the scatter of the next); then compound 1.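

In this assay, putting 2-chloro-4-fluorobenzyl in place of 4-chlorophenoxy on this aromatic carbon gives a 3.5-fold lower number from compound 1 to compound 3 (0.54 log units; beyond the scatter), a modest step that lies beyond the usual scatter. Going by these compounds alone, this is the first comparison here in which only one place on the shared core changes, so it shows that a swap at this position alone can move the read-out, something the earlier pair of compounds could not show. No measurement at hand says what lies behind the fall.

The swap exchanges the oxygen link for a carbon link and alters the halogens on the ring in the same step, so the compounds shown leave open which of these changes carries the fall, a question that a 4-chlorobenzyl group at this place could help to separate. Also open, going by these compounds, is how the read-out would respond to a group of a different kind on this carbon, such as an amine or a carboxylic acid.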